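The compounds below may be only part of what the source reports. "The series", "measured", "known", "first", "only" and "open" are said of these compounds alone.

Compound 2, with the structure `OCCCc1nc(Nc2ccc(C(F)(F)F)cc2)c2ccc(-c3ncccc3C(F)(F)F)cc2n1`, sets the reference point. Going by the values given here, in a functional assay for antagonist activity at transient receptor potential cation channel subfamily V member 1 (Homo sapiens) (on this read-out lower numbers stand for stronger inhibition and higher numbers for weaker inhibition), compound 2 gives 25 nM, the lowest of the three numbers measured so far. Compound 1, `O=C(O)COCc1nc(Nc2ccc(C(F)(F)F)cc2)c2ccc(-c3ncccc3C(F)(F)F)cc2n1`, carries a carboxymethoxy group where compound 2 carries 2-hydroxyethyl; in this assay compound 1 gives 81 nM, and the step of a 3.2-fold lower number from compound 1 to compound 2 (0.51 log units; beyond the scatter) is modest but beyond the scatter. Compound 3, `CNCc1nc(Nc2ccc(C(F)(F)F)cc2)c2ccc(-c3ncccc3C(F)(F)F)cc2n1`, carries methylamino at the same place and gives 26 nM in this assay, so the step of a 3.1-fold lower number from compound 1 to compound 3 (0.49 log units; beyond the scatter) is of the same size, while the step of a 1.0-fold higher number from compound 2 to compound 3 (0.02 log units; within the scatter) stays within the scatter.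

Compound 4, `CC(C)NCc1nc(Nc2ccc(C(F)(F)F)cc2)c2ccc(-c3ncccc3C(F)(F)F)cc2n1`, has not yet been measured. Its difference from compound 2 is isopropylamino in place of 2-hydroxyethyl on a saturated chain carbon bound to an aromatic carbon. Among the compounds with values here, the step that bears most on it is the one from compound 2 to compound 3, since compound 3 already carries a small amino group on that saturated chain carbon and that exchange changed nothing beyond the scatter. Within the data shown here, only one measured step touches an amino group there, so the expectation rests on a single comparison. On that basis the step of a 1.2-fold higher number from compound 2 to compound 4 (0.08 log units; within the scatter) is expected to be small. Compound 4 is therefore estimated at 30 nM in this assay, with a likely range from 10 nM to 90 nM.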

Compound 4, half-maximal inhibitory concentration: 35 nM
For compound 4 the middle estimate is 1.2-fold (0.07 log units) below the measured one; the measured number falls inside the stated range.
By their numbers in this assay, from the lowest: compounds 2, 3 and 4 (each within the scatter of the next); then compound 1.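

Changing the group on the amine nitrogen from methyl to isopropyl, a larger group, leaves the number in this assay within the scatter (a 1.3-fold higher number from compound 3 to compound 4 (0.13 log units; within the scatter)), so this assay does not separate these two amine substituents. The isopropylamino compound also stays within the scatter of the compound with the 2-hydroxyethyl group (a 1.4-fold higher number from compound 2 to compound 4 (0.15 log units; within the scatter)), while the gap to the carboxymethoxy compound remains beyond the scatter (a 2.3-fold lower number from compound 1 to compound 4 (0.36 log units; beyond the scatter)), so a second amine now sits with compound 2 and apart from compound 1. No data are available here to explain these numbers.

On these data alone, whether a much larger group on the amine nitrogen, such as cyclohexyl, or a second group on that nitrogen, as in dimethylamino, would keep the number in this range remains open. The compounds shown also leave open whether the higher number of compound 1 goes with its carboxylic acid or with the ether oxygen in its chain, a question that a methoxymethyl group at the same place could help to settle.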